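The source may hold more compounds than are shown below. What is called first, only, known or untested is meant among the compounds shown, and "the series" means these compounds.

In a functional assay on HOP-62 cells (Homo sapiens) for inhibition, read by sulforhodamine B assay (on this read-out higher numbers stand for weaker inhibition of growth and lower numbers for stronger inhibition of growth), compound 1 (`c1ccc(-c2ccc(-c3ccc(-c4nc5ccccc5[nH]4)cc3)cc2)cc1`) gives 100000 nM and compound 2 (`Cc1ccc2[nH]c(-c3ccc(-c4ccc(-c5ccc(N(C)C)cc5)cc4)cc3)nc2c1`) gives 4230 nM. Compound 3 (`Fc1ccc(-c2ccc(-c3ccc(-c4nc5ccccc5[nH]4)cc3)cc2)cc1`) gives 39300 nM, the second highest of the three numbers and nearer to the value of compound 1 than to that of compound 2. Compound 4 (`FC(F)(F)c1ccc(-c2ccc(-c3ccc(-c4nc5ccccc5[nH]4)cc3)cc2)cc1`) has not yet been measured. It differs from compound 3 by trifluoromethyl in place of fluoro on an aromatic carbon, with trifluoromethyl in place of fluoro on an aromatic carbon. Among the compounds with values here, no measured step makes this exact exchange. The closest evidence is fluoro in place of hydrogen on an aromatic carbon, which gave a 2.5-fold lower number from compound 1 to compound 3 (0.41 log units; beyond the scatter), a modest step beyond the scatter. Compound 2 differs from the others in more than one place and so says little about this change. A similarly modest move towards a lower number is therefore expected in this assay, and the estimated step is a 2.2-fold lower number from compound 3 to compound 4 (0.34 log units; beyond the scatter). For compound 4 the estimated value is 18000 nM, with an expected range of 6000 nM to 60000 nM.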

Compound 4, concentration for 50% growth inhibition: 100000 nM
Compound 4: middle estimate off by 5.6-fold (0.74 log units), on the low side; the whole stated range lies below it.
By their numbers in this assay, from the lowest: compound 2; then compound 3; then compounds 1 and 4 (each within the scatter of the next).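

In this assay, this position does not respond to halogen-bearing groups in one direction: the change from 4-fluorophenyl to 4-(trifluoromethyl)phenyl gives a 2.5-fold higher number from compound 3 to compound 4 (0.41 log units; beyond the scatter), the reverse direction of a 2.5-fold lower number from compound 1 to compound 3 (0.41 log units; beyond the scatter) for fluoro in place of hydrogen. Trifluoromethyl in place of hydrogen gives no change at the digits printed from compound 1 to compound 4 (within the scatter), so on this aromatic carbon, para to a large group, the lower number seen with fluoro does not extend to trifluoromethyl. No measurement at hand accounts for this difference between the two groups.

The compounds shown leave open how other groups at this position would read, such as an amine, a methoxy group or a carboxylic acid. They also leave open whether chloro, a single halogen atom like fluoro, would track fluoro or trifluoromethyl.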